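A halogen swap on the aryl ring and microsomal stability

The source may report more compounds than this note shows. Statements on the series, on what has been measured and on what is new or still open speak of the compounds shown alone.

Compound 1 `Nc1nc(NCCNc2ncc(-c3ncc[nH]3)c(-c3ccc(Cl)cc3)n2)ccc1[N+](=O)[O-]` was tested in an ADME assay on microsomes from liver (Rattus norvegicus) for metabolic stability; on this read-out lower numbers stand for a shorter-lived compound and higher numbers for a longer-lived compound. For compound 1 the result is a limit of the assay, > 0.5 h, not a number. Compound 2 `Nc1nc(NCCNc2ncc(-c3ncc[nH]3)c(-c3ccc(F)cc3C(F)(F)F)n2)ccc1[N+](=O)[O-]` carries 4-fluoro-2-(trifluoromethyl)phenyl in place of 4-chlorophenyl on an aromatic carbon. In this assay compound 2 likewise reaches only a limit, > 0.5 h. The step that the two limits leave unreadable from compound 1 to compound 2 cannot be sized because of the limit of > 0.5 h in this assay, at which 2 of the 2 values shown sit. Compound 3 `Nc1nc(NCCNc2ncc(-c3ncc[nH]3)c(-c3ccc(Br)cc3F)n2)ccc1[N+](=O)[O-]` differs from compound 1 by 4-bromo-2-fluorophenyl in place of 4-chlorophenyl on an aromatic carbon. Within the data shown here, the single measured step, a step that the two limits leave unreadable from compound 1 to compound 2, gives no readable size or direction, so the only guide is that both measured compounds sit at the limit of the assay. Compound 3 is therefore expected to give 1 h, within a range from 0.5 h to 3 h. The expected step that the limit leaves unreadable from compound 1 to compound 3 reflects an estimate that compound 3 will most likely again be reported only as a limit.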

Compound 3, half-life: > 0.5 h
Compound 3: only a limit was reported; the forecaster's own chance of this, stated with the estimate: 75%; the middle value does not contradict the limit.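

Compound 3 adds no readable step: its comparisons with compound 1 and compound 2 cannot be sized, because all three compounds sit at one limit of this assay: the limit of > 0.5 h in this assay, at which 3 of the 3 values shown sit.

From the compounds shown here alone, how long compound 1, compound 2 and compound 3 actually last in this assay, and whether their aryl groups make any difference there, stays open.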